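The source may report more compounds than this note shows. Statements on the series, on what has been measured and on what is new or still open speak of the compounds shown alone.

Compound 1 `CCCCN(CC)c1cc(C)nc2c1NC(=O)CN2c1ccc(C)cc1Cl` gives 4.4 nM in an assay on HEK-293T cells for displacement of a labelled ligand from corticotropin-releasing factor receptor 1 (Homo sapiens), read by scintillation counting, with a stated time of 2 h; a lower number here means a stronger inhibitor, a higher number a weaker inhibitor.
Compound 2 `CCCCN(CC)c1cc(C)nc2c1NC(=O)CN2c1ccc(Br)cc1Cl` gives 2.7 nM.
Compound 3 `CCCCN(CC)c1cc(C)nc2c1NC(=O)CN2c1ccc(OC)cc1C` gives 4 nM.

These three compounds share one core and differ only in the aryl group carried on the ring nitrogen. Compound 1 sits close to both partners: a 1.6-fold lower number from compound 1 to compound 2 (0.21 log units; within the scatter) and a 1.1-fold lower number from compound 1 to compound 3 (0.04 log units; within the scatter), so nothing beyond the scatter separates it from either. Compound 4 `CCCCN(CC)c1cc(C)nc2c1NC(=O)CN2c1ccc(Cl)cc1C` is the next member of the set, not yet measured. It differs from compound 1 in that (4-chloro-2-methylphenyl in place of 2-chloro-4-methylphenyl on a nitrogen on an aromatic ring in a ring). Among the compounds with values here, two measured steps bear on this change, each an exchange of the whole aryl group on the same nitrogen: a 1.1-fold lower number from compound 1 to compound 3 (0.04 log units; within the scatter) and a 1.5-fold higher number from compound 2 to compound 3 (0.17 log units; within the scatter). Both lie within the scatter, and the three measured aryl groups, carrying chloro, bromo, methyl or methoxy, all land close together. Rearranging the same chloro and methyl on the ring is thus expected to leave the number essentially where it is, and a 1.3-fold lower number from compound 1 to compound 4 (0.10 log units; within the scatter) is the expected step. For compound 4 the estimate in this assay is 3.5 nM, with a range of 1.5 nM to 8 nM.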

Compound 4, inhibition constant: 5.4 nM
Compound 4: middle estimate off by 1.5-fold (0.19 log units), on the low side; the range from low to high includes it.
By their numbers in this assay, from the lowest: compounds 2, 3, 1 and 4 (each within the scatter of the next).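

In this assay, moving from 2-chloro-4-methylphenyl to 4-chloro-2-methylphenyl on this nitrogen joins the same atoms differently, yet it gives a 1.2-fold higher number from compound 1 to compound 4 (0.09 log units; within the scatter), so the two arrangements cannot be told apart here. The other two new steps, a 1.4-fold higher number from compound 3 to compound 4 (0.13 log units; within the scatter) and a 2.0-fold higher number from compound 2 to compound 4 (0.30 log units; within the scatter), are also printed as within the scatter, and the second is the largest gap among the four compounds, so all four aryl groups remain indistinguishable in this assay. No measurement shown offers an explanation for this result.

The aryl groups shown carry only chloro, bromo, methyl or methoxy, so it remains open whether the number would hold with a carboxylic acid, an amine or a longer chain there. As far as these compounds go, the rest of the shared core is identical in all four compounds, so changes elsewhere also remain open.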